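This account rests on a few compounds, and the source may have more. Where it says the series, first, only, none or still open, it means among the compounds named here.

In a functional assay on NCI-H226 cells (Homo sapiens) for inhibition, read by sulforhodamine B assay, with a stated time of 48 h (on this read-out lower numbers stand for higher toxicity in this test and higher numbers for lower toxicity in this test), compound 1 `COc1ccc(-c2cc(/C=C/C(=O)c3ccc(N)cc3)[nH]n2)cc1` gives 92100 nM, and compound 2 `COc1cc(-c2cc(/C=C/C(=O)c3ccc(N)cc3)[nH]n2)cc(OC)c1OC` gives 7180 nM. Compound 3 `COc1cc(-c2cc(/C=C/C(=O)c3ccc(Cl)c(Cl)c3)[nH]n2)cc(OC)c1OC` gives > 100000 nM, which is a limit of the assay and not a number; it sits at the limit of > 100000 nM in this assay, at which 1 of the 3 values shown sits. Among the compounds with values here, the change an at least 13-fold higher number from compound 2 to compound 3 (1.14 log units; beyond the scatter) is the only single-point step among the measured compounds. Among the numbers shown, compound 2 has the lowest value, with compound 1 as the nearest of the measured numbers.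

Compound 4 `COc1ccc(-c2cc(/C=C/C(=O)c3ccc(N)cc3)[nH]n2)cc1OC` differs from compound 2 by hydrogen in place of methoxy on an aromatic carbon. Within the data shown here, no measured step touches a methoxy group: the step from compound 2 to compound 3 concerns the group on the carbonyl carbon and does not bear on this change. What remains is that compound 1 and compound 2 differ in how many methoxy groups the aryl ring carries, and compound 4 carries an intermediate number of them. Compound 4 is therefore expected to give a value lying in the middle of those two, that is a 3.5-fold higher number from compound 2 to compound 4 (0.54 log units; beyond the scatter) in the direction of compound 1. For compound 4 the estimate in this assay is 25000 nM, with a range from 8000 nM to 80000 nM.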

Compound 4, concentration lethal to 50% of the cells: 76200 nM
Compound 4: the middle estimate sits 3.0-fold (0.48 log units) below what was measured; the range from low to high includes it.
By their numbers in this assay, from the lowest: compound 2; then compounds 4 and 1 (each within the scatter of the next). At a limit, above all of these: compound 3.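

In this assay, within the data shown here, taking away the one methoxy group that sits ortho to a methoxy group and meta to another gives an 11-fold higher number from compound 2 to compound 4 (1.03 log units; beyond the scatter), so this single position carries a large part of the low number of compound 2. Methoxy in place of hydrogen on an aromatic carbon gives a 1.2-fold lower number from compound 1 to compound 4 (0.08 log units; within the scatter), so that change alone leaves the number unmoved, and the low number appears only once the third methoxy group is present. Nothing in the data offers a reason for this difference between the two methoxy steps.

On these data alone, whether a hydroxy group, an ethoxy group or a fluorine atom on this aromatic carbon would hold the low number of compound 2 stays open. So does whether this methoxy group counts as much with a group other than 4-aminophenyl on the carbonyl carbon.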